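Methylphenyl swaps in a small series

The compounds below may be only part of what the source reports. "The series", "measured", "known", "first", "only" and "open" are said of these compounds alone.

Measured in a functional assay on A549 cells (Homo sapiens) for inhibition, read by MTT assay, with a stated time of 72 h; on this read-out higher numbers stand for weaker inhibition and lower numbers for stronger inhibition:
compound 1 `Cc1ccc(CN2CCc3ncn(COCc4ccccc4)c3/C(=C/c3ccccc3)C2=O)cc1`: 11400 nM
compound 2 `O=C1/C(=C\c2ccccc2)c2c(ncn2COCc2ccccc2)CCN1Cc1ccc(F)cc1`: 19600 nM
compound 3 `Cc1cccc(CN2CCc3ncn(COCc4ccccc4)c3/C(=C/c3ccccc3)C2=O)c1`: 16100 nM

Compound 3 is not separated from the other two measured compounds. The data show a 1.4-fold higher number from compound 1 to compound 3 (0.15 log units; within the scatter) and a 1.2-fold lower number from compound 2 to compound 3 (0.09 log units; within the scatter). Compound 4 `Cc1ccccc1CN1CCc2ncn(COCc3ccccc3)c2/C(=C/c2ccccc2)C1=O` has not yet been measured. Its difference from compound 3 is 2-methylphenyl in place of 3-methylphenyl on a saturated chain carbon bound to an amide-type nitrogen in a ring.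

The closest measured precedent is 3-methylphenyl in place of 4-methylphenyl at that same place, which gave a 1.4-fold higher number from compound 1 to compound 3 (0.15 log units; within the scatter). Fluoro in place of methyl gave a 1.7-fold higher number from compound 1 to compound 2 (0.24 log units; within the scatter). Among the measured compounds shown here, no measured compound carries the 2-methylphenyl group, so this precedent is indirect. No step beyond the scatter is expected in this assay, and the data indicate no direction. The estimated 1.1-fold lower number from compound 3 to compound 4 (0.03 log units; within the scatter) is correspondingly small. Compound 4 is expected at 15000 nM, with an estimated range of 8000 nM to 28000 nM.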

Compound 4, half-maximal inhibitory concentration: 25600 nM
Estimate against measurement, compound 4: 1.7-fold (0.23 log units) below; the range from low to high includes it.
By their numbers in this assay, from the lowest: compounds 1, 3, 2 and 4 (each within the scatter of the next, the first and the last beyond it).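

In this assay, among the compounds shown here, 2-methylphenyl in place of 4-methylphenyl gives the first step that is beyond the scatter (a 2.2-fold higher number from compound 1 to compound 4 (0.35 log units; beyond the scatter)), so compound 4 is a weaker inhibitor than compound 1. The other two steps do not separate compound 4 from its neighbours (a 1.6-fold higher number from compound 3 to compound 4 (0.20 log units; within the scatter); a 1.3-fold higher number from compound 2 to compound 4 (0.12 log units; within the scatter)), so among the three methylphenyl groups only the 2-methylphenyl and 4-methylphenyl groups are told apart, with 3-methylphenyl resolved from neither. Nothing available accounts for this separation.

Open, on these data alone, is how a 2-methoxyphenyl or 2-chlorophenyl group would compare with 2-methylphenyl at this place. Also open, as far as these compounds go, is whether a carboxylic acid or an amine on the same phenyl ring would give a larger step in this assay.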